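A few compounds are considered here, and "the series" means these few. Any claim that something is new, unique, unknown or untested is made for them only; others in the source may bear on it.

Compound 1 `Fc1ccccc1C1Cc2nccn2C1`: 2
Compound 2 `Clc1ccccc1C1CCc2nc[nH]c2C1`: 3.1
Compound 3 `COc1ccccc1C1CCc2nc[nH]c2C1`: 2.8

In a physicochemical assay for lipophilicity, at pH 7.4 (a lower number here means a more polar compound, a higher number a more lipophilic compound), compound 1 gives 2 and so stands lowest of the three, with compound 3 and compound 2 both higher, beyond the scatter. The change to compound 4 `N#Cc1ccccc1C1Cc2nccn2C1` is cyano in place of fluoro on an aromatic carbon on the core of compound 1: cyano in place of fluoro on an aromatic carbon. For the measured compounds named here, the only measured step, a number 0.30 log units lower from compound 2 to compound 3 (within the scatter) for methoxy in place of chloro on an aromatic carbon, bears on it loosely. Going by the values given here, it involves other groups on another core, and no measured step involves cyano. On this slim evidence a modest downward move in this assay is expected, and the estimated step is a number 0.40 log units lower from compound 1 to compound 4 (beyond the scatter) at its centre. Compound 4 is estimated at 1.6 (range 1.1 to 2.1).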

Compound 4, distribution coefficient: 1.3
The estimate for compound 4 lay 0.30 log units above the measured number; measured number inside the range.
By their numbers in this assay, from the lowest: compound 4; then compound 1; then compounds 3 and 2 (each within the scatter of the next).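

At this place on the six-membered aromatic ring, ortho to a group of 8 heavy atoms, cyano in place of fluoro gives in this assay a number 0.70 log units lower from compound 1 to compound 4 (beyond the scatter) on the core of compound 1. For the compounds shown here, the only earlier step, a number 0.30 log units lower from compound 2 to compound 3 (within the scatter) for methoxy in place of chloro on another core, did not show a change of this kind beyond the scatter. No measurement shown gives a reason for the size of the new step.

As far as these compounds go, whether cyano in place of fluoro moves the number as far on the core of compound 2 remains open. So does how an amine or a carboxylic acid at this place would read in this assay.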